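The source may hold more compounds than are shown below. What is called first, only, known or untested is meant among the compounds shown, and "the series" means these compounds.

In a functional assay on A549 cells (Homo sapiens) for antiproliferative activity, read by MTT assay, with a stated time of 72 h (a higher number here means a weaker inhibitor, a lower number a stronger inhibitor), compound 1 (`O=C(N/N=C/c1ccc(Br)cc1)Nc1ccc(Oc2ccnc3[nH]ccc23)c(F)c1`) gives 820 nM, compound 2 (`O=C(N/N=C/c1cc(Br)c(O)c(Br)c1)Nc1ccc(Oc2ccnc3[nH]ccc23)c(F)c1`) gives 16200 nM and compound 3 (`O=C(N/N=C/c1ccc(Br)cc1)Nc1ccc(Oc2ccnc3[nH]ccc23)cc1`) gives 640 nM. Compound 3 thus sits level with compound 1, well under compound 2. Compound 4 (`COc1ccc(/C=N/NC(=O)Nc2ccc(Oc3ccnc4[nH]ccc34)cc2)cc1`) carries methoxy in place of bromo on an aromatic carbon, para to a large group: methoxy in place of bromo on an aromatic carbon. For the measured compounds named here, no measured step makes this exact change. The closest, a 20-fold higher number from compound 1 to compound 2 (1.30 log units; beyond the scatter), alters the same 4-bromophenyl group but is a larger replacement, while a 1.3-fold lower number from compound 1 to compound 3 (0.11 log units; within the scatter) involves the fluoro and so says little here. Only a modest rise is therefore expected, estimated as a 1.6-fold higher number from compound 3 to compound 4 (0.19 log units; within the scatter). Compound 4 is expected at 1000 nM, with an estimated range of 300 nM to 4000 nM.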

Compound 4, half-maximal inhibitory concentration: 4300 nM
Estimate against measurement, compound 4: 4.3-fold (0.63 log units) below; measured number outside the range, above it.
By their numbers in this assay, from the lowest: compounds 3 and 1 (each within the scatter of the next); then compound 4; then compound 2.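

In this assay, exchanging a single group on the 4-bromophenyl ring, para to a large group, already moves the number beyond the scatter: methoxy in place of bromo gives a 6.7-fold higher number from compound 3 to compound 4 (0.83 log units; beyond the scatter). The earlier step at this ring replaced the whole group with 3,5-dibromo-4-hydroxyphenyl, so it could not show the effect of the bromo alone. No measurement at hand accounts for this rise. From the compounds shown here alone, whether an amine or an ethoxy group at this position would give a number closer to that of compound 3 remains open, as does whether the same exchange gives a similar step with the fluoro of compound 1 present.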